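This account rests on a few compounds, and the source may have more. Where it says the series, first, only, none or still open, it means among the compounds named here.

In a functional assay on HepG2 cells (Homo sapiens) for antiproliferative activity, read by CCK-8 assay, with a stated time of 72 h (a lower number here means a stronger inhibitor, a higher number a weaker inhibitor), compound 2 `Nc1ccccc1NC(=O)c1ccc(COc2ccc(Cl)cc2)cc1` gives > 32000 nM, which is a limit and not a number. Compound 1 `Nc1ccccc1NC(=O)c1ccc(COc2ccc([N+](=O)[O-])cc2)cc1` gives > 32000 nM, also a limit. Compound 3 `Nc1ccccc1NC(=O)/C=C/c1ccc(COc2ccccc2)cc1` gives > 32000 nM, again a limit. Compound 2 therefore has no readable place in the series, which stands entirely at the limit of > 32000 nM in this assay, at which 3 of the 3 values shown sit.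

Compound 4 `CCc1ccc(OCc2ccc(C(=O)Nc3ccccc3N)cc2)cc1` differs from compound 2 by one substituent: ethyl in place of chloro on an aromatic carbon. Going by the values given here, the only measured step touching this substituent is a step that the two limits leave unreadable from compound 1 to compound 2, so it offers no size to carry over. Among the compounds with values here, no step of known size or direction can therefore be expected in this assay. The expectation for compound 4 rests on compound 2, whose > 32000 nM is a limit, and on the absence of any readable value in the series. The expected change is a step that the limit leaves unreadable from compound 2 to compound 4. The estimate for compound 4 is 45000 nM, with an expected range of 14000 nM to 120000 nM.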

Compound 4, half-maximal inhibitory concentration: 6960 nM
Beside the measured number, compound 4's estimate is 6.5-fold (0.81 log units) above it; the whole stated range lies above it.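

The place on the six-membered aromatic ring, para to a large group, can therefore move the read-out in this assay, which neither the chloro nor the nitro compound could show: with ethyl there, the series gives an at least 4.5-fold lower number from compound 2 to compound 4 (0.66 log units; beyond the scatter), and likewise an at least 4.5-fold lower number from compound 1 to compound 4 (0.66 log units; beyond the scatter). Both steps start from limits, so they fix only a smallest size, while the step between the chloro and nitro compounds still cannot be read. Compound 4 is also the only compound here with a readable number, and the rest of the series stays at its ceiling: the limit of > 32000 nM in this assay, at which 3 of the 4 values shown sit.

The compounds shown leave open whether this drop belongs to ethyl alone or would extend to methyl or to a longer chain such as propyl. They also leave open how an amine or a carboxylic acid at the same place would read.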